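This account rests on a few compounds, and the source may have more. Where it says the series, first, only, none or still open, it means among the compounds named here.

Working notes on the series. Compound 2 `COc1ccc(C(=O)/C=C/c2cccc(F)c2)c2c1C=CC(C)(C)O2` reaches only the upper limit of a functional assay on K562 cells (Homo sapiens) for antiproliferative activity, read by MTT assay, with a stated time of 24 h; on this read-out lower numbers stand for stronger inhibition and higher numbers for weaker inhibition: compound 2 gives the limit > 10000 nM and no number. Compound 1 `COc1cc(OC)c(OC)cc1/C=C/C(=O)c1ccc(OC)c2c1OC(C)(C)C=C2` in this assay likewise gives only the limit > 10000 nM. Compound 3 `COc1ccc(C(=O)/C=C/c2cccc(C(F)(F)F)c2)c2c1C=CC(C)(C)O2` gives a number in this assay, 7850 nM. Among the measured compounds shown here, the one measured step that starts from compound 2 is an at least 1.2-fold lower number from compound 2 to compound 3 (0.10 log units; that floor lies within the scatter); its floor lies within the scatter and it rests on (the limit of > 10000 nM in this assay, at which 2 of the 3 values shown sit), so it carries little weight.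

Compound 4 `COc1ccc(C(=O)/C=C/c2ccsc2)c2c1C=CC(C)(C)O2` differs from compound 2 by thiophen-3-yl in place of 3-fluorophenyl on a double-bonded chain carbon bound to a double-bonded chain carbon. For the measured compounds named here, no measured step bears on this exchange directly; the ring that enters occurs nowhere else in the set, and the only step from compound 2 was small. Since compound 2 stands at the limit, a recorded move in this assay can only go downward. Compound 4 is therefore expected to stay near the limit, with an estimated 9000 nM (range 4000 nM to 20000 nM). That estimate means an expected step of an at least 1.1-fold lower number from compound 2 to compound 4 (0.04 log units; that floor lies within the scatter), none beyond the scatter.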

Compound 4, half-maximal inhibitory concentration: > 10000 nM
Compound 4 gave a limit, no number; the forecaster's own chance of this, stated with the estimate: 55%; middle value at least 1.1-fold (0.04 log units) from the limit.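

Among the compounds shown here, compound 2 and compound 4 both give only a limit in this assay, and no step between them can be read. The compounds shown leave open how thiophen-3-yl and 3-fluorophenyl compare on this read-out, with most values resting on one limit: the limit of > 10000 nM in this assay, at which 3 of the 4 values shown sit.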